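Swapping the aryl group on the hydrazone carbon

The source may hold more compounds than are shown below. What is called first, only, known or untested is meant among the compounds shown, and "the series" means these compounds.

Compound 1 `CN(C)CCn1cnnc1-c1cc(Oc2ccc(NC(=O)N/N=C/c3ccc(O)c(Br)c3)cc2F)ccn1` is the starting point. In a functional assay on A549 cells (Homo sapiens) for cytotoxicity, read by MTT assay, with a stated time of 72 h (on this read-out lower numbers stand for stronger inhibition and higher numbers for weaker inhibition), compound 1 gives 1370 nM, a number that sits within the usual scatter of both measured companions. Compound 2 `CN(C)CCn1cnnc1-c1cc(Oc2ccc(NC(=O)N/N=C/c3c(O)ccc4ccccc34)cc2F)ccn1` gives 880 nM, and compound 3 `Cc1cc(/C=N/NC(=O)Nc2ccc(Oc3ccnc(-c4nncn4CCN(C)C)c3)c(F)c2)cc(C)c1O` gives 1640 nM. The move to compound 4 `CN(C)CCn1cnnc1-c1cc(Oc2ccc(NC(=O)N/N=C/c3ccc(O)cc3O)cc2F)ccn1` is 2,4-dihydroxyphenyl in place of 3-bromo-4-hydroxyphenyl on a carbon with a double bond to nitrogen. Among the measured compounds shown here, two measured steps touch the same place on the shared core: a 1.6-fold lower number from compound 1 to compound 2 (0.19 log units; within the scatter) and a 1.2-fold higher number from compound 1 to compound 3 (0.08 log units; within the scatter). Neither crossed the scatter, so exchanging the group on this carbon has so far left the cytotoxicity number roughly where it was. No step beyond the scatter is therefore expected for compound 4, a 1.1-fold lower number from compound 1 to compound 4 (0.02 log units; within the scatter). Compound 4 is estimated at 1300 nM, with a range from 600 nM to 3000 nM.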

Compound 4, half-maximal inhibitory concentration: 12700 nM
The estimate for compound 4 lay 9.8-fold (0.99 log units) below the measured number; measured number outside the range, above it.
By their numbers in this assay, from the lowest: compounds 2, 1 and 3 (each within the scatter of the next); then compound 4.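

In this assay, among the compounds shown here, the switch to 2,4-dihydroxyphenyl is the first change on this carbon to pass the scatter: a 9.3-fold higher number from compound 1 to compound 4 (0.97 log units; beyond the scatter) and a 7.7-fold higher number from compound 3 to compound 4 (0.89 log units; beyond the scatter) and also a 14-fold higher number from compound 2 to compound 4 (1.16 log units; beyond the scatter) for the same exchange of aryl group. So the group on this carbon can strongly change the number, and the range of groups shown earlier gave no sign of that. No measurement at hand explains this step.

Among these groups only 2,4-dihydroxyphenyl carries two hydroxy groups, but one compound cannot show whether that feature matters. From the compounds shown here alone, how a methoxy or an amino group would behave in place of a hydroxy group on that ring remains open.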